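Removing the methyl from a methoxy on a shared aryl core

The source may report more compounds than this note shows. Statements on the series, on what has been measured and on what is new or still open speak of the compounds shown alone.

Compound 1, `C/C=C\Oc1cncc(N2CCCNCC2)c1`: 2090 nM
Compound 2, `Oc1cc(N2CCCNCC2)cnc1I`: 479 nM
Compound 3, `COc1cncc(N2CCCNCC2)c1`: 1410 nM

All three compounds were tested in a functional assay on HEK293 cells for agonist activity at Neuronal acetylcholine receptor; alpha4/beta2 (Homo sapiens), read by FLIPR and calcium flux; on this read-out lower numbers stand for an effect already at smaller amounts and higher numbers for an effect only at larger amounts of compound. Among the three numbers, compound 3 holds the second highest. Among the compounds with values here, its nearest neighbour is compound 1, and the only measured step that touches compound 3 is a 1.5-fold lower number from compound 1 to compound 3 (0.17 log units; within the scatter), a change in which the group on the ring oxygen was shortened to methyl without any movement beyond the scatter. Compound 2, which carries a hydroxy and an iodine on its core, differs from compound 3 in more than one place, and gives a number lower than compound 3 by a margin beyond the scatter.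

The next compound, compound 4, `Oc1cncc(N2CCCNCC2)c1`, arises from compound 3 by hydrogen in place of methyl on an oxygen on an aromatic ring. Within the data shown here, the one measured step on this oxygen, from compound 1 to compound 3, was small; removing the remaining methyl is a further trimming of the same group, so the expected step of a 1.2-fold lower number from compound 3 to compound 4 (0.07 log units; within the scatter) in this assay is also small, with no clear direction. Compound 4 is therefore expected to give about 1200 nM, between 350 nM and 4000 nM.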

Compound 4, half-maximal effective concentration: 141 nM
For compound 4 the middle estimate is 8.5-fold (0.93 log units) above the measured one; the measured number lies below the stated range.
By their numbers in this assay, from the lowest: compound 4; then compound 2; then compounds 3 and 1 (each within the scatter of the next).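

Going from methoxy to hydroxy gives a 10-fold lower number from compound 3 to compound 4 (1.00 log units; beyond the scatter) in this assay, so the last methyl on this oxygen matters far more than the earlier change from prop-1-en-1-yl to methyl, which stayed within the scatter. Starting from the longer group, replacing prop-1-en-1-yl with hydrogen gives a 15-fold lower number from compound 1 to compound 4 (1.17 log units; beyond the scatter), and among the compounds shown, both groups on this oxygen go with higher numbers than the free hydroxy. Iodo also matters on the hydroxy compounds, since hydrogen in place of iodo on an aromatic carbon gives a 3.4-fold lower number from compound 2 to compound 4 (0.53 log units; beyond the scatter).

As far as these compounds go, whether an amine or a carboxylic acid in place of the hydroxy would keep a number this low remains open. Nothing measured here explains why such a small change has so large an effect.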